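From Hexylamino to 4-Methylpiperazin-1-yl on the Carbonyl Carbon

A few compounds are considered here, and "the series" means these few. Any claim that something is new, unique, unknown or untested is made for them only; others in the source may bear on it.

In a functional assay on B16-F10 cells (Mus musculus) for inhibition, read by MTT assay, with a stated time of 48 h (a lower number here means a stronger inhibitor, a higher number a weaker inhibitor), compound 3 (`CCCCCCNC(=O)/C=C/c1c(/C=C/c2ccc(OC)cc2)cc(OC)cc1OC`) gives 7180 nM. Compound 1 (`COc1ccc(/C=C/c2cc(OC)cc(OC)c2/C=C/C(=O)N2CCCCC2C)cc1`) gives 7660 nM, and compound 2 (`COc1ccc(/C=C/c2cc(OC)cc(OC)c2/C=C/C(=O)NC(C)C)cc1`) gives 4020 nM, so compound 3 lies within the scatter of both. Compound 4 (`COc1ccc(/C=C/c2cc(OC)cc(OC)c2/C=C/C(=O)N2CCN(C)CC2)cc1`) carries 4-methylpiperazin-1-yl in place of hexylamino on a carbonyl carbon. Three measured steps changed the group at this place: a 1.1-fold lower number from compound 1 to compound 3 (0.03 log units; within the scatter), a 1.8-fold higher number from compound 2 to compound 3 (0.25 log units; within the scatter) and a 1.9-fold lower number from compound 1 to compound 2 (0.28 log units; within the scatter). None of these compounds carries 4-methylpiperazin-1-yl, so the precedent is limited. No change beyond the scatter is therefore expected in this assay, and the expected move is a 1.2-fold lower number from compound 3 to compound 4 (0.08 log units; within the scatter). For compound 4, the estimated value is 6000 nM, with an expected range of 2500 nM to 14000 nM.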

Compound 4, half-maximal inhibitory concentration: 5670 nM
For compound 4 the middle estimate is 1.1-fold (0.02 log units) above the measured one; the measured number falls inside the stated range.
By their numbers in this assay, from the lowest: compounds 2, 4, 3 and 1 (each within the scatter of the next).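

In this assay, 4-methylpiperazin-1-yl on the carbonyl carbon loses the hydrogen-bond donor of hexylamino and brings in a second ring nitrogen, yet the result is a 1.3-fold lower number from compound 3 to compound 4 (0.10 log units; within the scatter). The other two comparisons, a 1.4-fold higher number from compound 2 to compound 4 (0.15 log units; within the scatter) and a 1.4-fold lower number from compound 1 to compound 4 (0.13 log units; within the scatter), also stay within the scatter, so this place has not yet shown a step beyond it, even with this new ring. No evidence given here bears on this result.

From the compounds shown here alone, it remains open whether an anilino group, an unsubstituted piperazine or an amine carrying a carboxylic acid would give a step beyond the scatter.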